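The compounds below may be only part of what the source reports. "The series", "measured", "known", "first", "only" and "open" are said of these compounds alone.

The measured compounds:
Compound 1 `Nc1cc(N)c2nc(-c3ccccc3)c(NCc3ccc(F)cc3)nc2c1` gives in a functional assay on MOLT-4 cells (Homo sapiens) for inhibition, read by sulforhodamine B assay, with a stated time of 48 h (on this read-out higher numbers stand for lower toxicity in this test and lower numbers for higher toxicity in this test), only a limit, < 100000 nM.
Compound 2 `COc1ccc(Sc2nc3cc(N)cc(N)c3nc2-c2ccccc2)cc1` gives in this assay only a limit, < 100000 nM.
Compound 3 `Nc1cc(N)c2nc(-c3ccccc3)c(Oc3ccc(F)cc3)nc2c1` gives in this assay only a limit, < 100000 nM.

Compound 3 therefore stands at a limit rather than at a number, and the same holds for the other two values shown: the limit of < 100000 nM in this assay, at which 3 of the 3 values shown sit. The change toward compound 4 `Nc1cc(N)c2nc(-c3ccccc3)c(Sc3ccc(F)cc3)nc2c1` touches one place: (4-fluorophenyl)sulfanyl in place of 4-fluorophenoxy on an aromatic carbon. The three steps already measured all run between limits, so a step that the two limits leave unreadable from compound 1 to compound 2, a step that the two limits leave unreadable from compound 1 to compound 3 and a step that the two limits leave unreadable from compound 2 to compound 3 carry no readable size. Compound 2 also carries a sulfanyl link, but its value is a limit as well, so the exchange of the linking oxygen for sulfur has no measured size anywhere in this set. Compound 4 is expected to sit at the same limit, estimated at 50000 nM with a range from 10000 nM to 100000 nM. The step this estimate implies, a step that the limit leaves unreadable from compound 3 to compound 4, is expected to stay within the scatter.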

Compound 4, concentration lethal to 50% of the cells: < 100000 nM
Compound 4 ended at the assay's limit; the forecaster's own chance of this, stated with the estimate: 80%; the middle value lies beyond the limit too.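

Compound 4 also gives only a limit in this assay, so no step between it and compound 1, compound 2 or compound 3 can be read: the limit of < 100000 nM in this assay, at which 4 of the 4 values shown sit.

The compounds shown leave open where each true value lies and how large any exchange, including (4-fluorophenyl)sulfanyl in place of 4-fluorophenoxy, really is.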